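This account rests on a few compounds, and the source may have more. Where it says the series, first, only, none or still open, it means among the compounds named here.

The measured compounds:

Compound 1 `COc1ccc(/C=C(\C)C(=O)/C=C/c2ccccc2)cc1` gives 54000 nM in an ADME assay on J774.A1 cells (Mus musculus) for cytotoxicity, read by MTT assay, with a stated time of 48 h; a higher number here means that more compound is tolerated, a lower number that less compound is tolerated.
Compound 2 `C/C(=C\c1ccc([N+](=O)[O-])cc1)C(=O)/C=C/c1ccccc1` gives 47300 nM in this assay.
Compound 3 `COc1ccc(/C=C/C(=O)/C(C)=C/c2ccc([N+](=O)[O-])cc2)cc1` gives 36600 nM in this assay.

All three share a chain of two carbon-carbon double bonds around a carbonyl, capped by a ring at each end. Compound 1 and compound 2 differ in one place, (nitro in place of methoxy on an aromatic carbon), and this gave a 1.1-fold lower number from compound 1 to compound 2 (0.06 log units; within the scatter). Compound 2 and compound 3 also differ in one place, methoxy in place of hydrogen on an aromatic carbon, and this gave a 1.3-fold lower number from compound 2 to compound 3 (0.11 log units; within the scatter). How compound 1 and compound 3 differ is not broken down here.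

Compound 4 `C/C(=C\c1ccc([N+](=O)[O-])cc1)C(=O)/C=C/c1ccc([N+](=O)[O-])cc1` is not yet measured. For the measured compounds named here, it differs from compound 3 by nitro in place of methoxy on an aromatic carbon, which is the same change as the one from compound 1 to compound 2, made at the same kind of place. Because that earlier step was a 1.1-fold lower number from compound 1 to compound 2 (0.06 log units; within the scatter), the step to compound 4 is expected to be of similar size, a 1.1-fold lower number from compound 3 to compound 4 (0.04 log units; within the scatter). Compound 4 is therefore estimated to give 33000 nM in this assay, most likely between 17000 nM and 66000 nM.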

Compound 4, half-maximal cytotoxic concentration: 43000 nM
Compound 4: the middle estimate sits 1.3-fold (0.11 log units) below what was measured; low and high end bracket the measured number.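

Setting nitro in place of methoxy on an aromatic carbon gave a 1.2-fold higher number from compound 3 to compound 4 (0.07 log units; within the scatter), and setting nitro in place of hydrogen gave a 1.1-fold lower number from compound 2 to compound 4 (0.04 log units; within the scatter). Carried from one core to the other, the swap of methoxy for nitro gave steps that agree in this assay: the same change on two cores in this assay, a 1.1-fold lower number (0.06 log units; within the scatter) from compound 1 to compound 2 and a 1.2-fold higher number (0.07 log units; within the scatter) from compound 3 to compound 4, 1.3-fold (0.13 log units) apart, within the scatter of two such steps

All of these steps lie within the scatter, so the data show a change that can be carried between these two cores with no visible shift in tolerated concentration, but they do not show a real effect of any set direction or size, and two cores are too few to make a rule for the series.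

On these data alone, the aromatic carbon in question carries only methoxy, nitro or hydrogen here, so an amine, a carboxylic acid or a chlorine atom in that place remains open. Also open, as far as these compounds go, is whether steps stay this small when the methyl group on the chain gives way to hydrogen or a longer chain.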